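The compounds below may be only part of what the source reports. "The series", "measured", "known", "first", "only" and "open" are said of these compounds alone.

Compound 2, `Cc1ccc(S(=O)(=O)/N=C(/CCNC2=CC(=O)c3ccccc3C2=O)Nc2ccc(Cl)cc2)cc1`, gives 65400 nM in an ADME assay on HEK293 cells (Homo sapiens) for cytotoxicity, read by MTT assay, with a stated time of 48 h (a higher number here means a weaker inhibitor, a lower number a stronger inhibitor), the highest of the three numbers recorded there, though its steps to its neighbours all lie within the scatter. Compound 1, `COc1ccc(N/C(CCNC2=CC(=O)c3ccccc3C2=O)=N\S(=O)(=O)c2ccc(C)cc2)cc1`, gives 35100 nM, and compound 3, `Cc1ccc(S(=O)(=O)/N=C(/CCNC2=CC(=O)c3ccccc3C2=O)Nc2ccccc2I)cc1`, gives 49400 nM. The steps among them are a 1.9-fold higher number from compound 1 to compound 2 (0.27 log units; within the scatter), a 1.4-fold higher number from compound 1 to compound 3 (0.15 log units; within the scatter) and a 1.3-fold lower number from compound 2 to compound 3 (0.12 log units; within the scatter), all within the scatter, so swapping one aryl group for another on the amine nitrogen has so far left this assay unmoved.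

Compound 4, `Cc1ccc(S(=O)(=O)/N=C(/CCNC2=CC(=O)c3ccccc3C2=O)NC2CCCCC2)cc1`, differs from compound 2 in one place: cyclohexyl in place of 4-chlorophenyl on an amine nitrogen. For the measured compounds named here, no measured step covers an exchange of an aromatic ring for a non-aromatic one on that nitrogen, so the three small aryl steps are the only guide, and they suggest no step beyond the scatter. Compound 4 is therefore expected to give about 55000 nM, between 25000 nM and 120000 nM, which is an estimated step of a 1.2-fold lower number from compound 2 to compound 4 (0.08 log units; within the scatter).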

Compound 4, half-maximal inhibitory concentration: 50100 nM
Compound 4: the middle estimate sits 1.1-fold (0.04 log units) above what was measured; the measured number falls inside the stated range.
By their numbers in this assay, from the lowest: compounds 1, 3, 4 and 2 (each within the scatter of the next).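

The steps of a 1.3-fold lower number from compound 2 to compound 4 (0.12 log units; within the scatter) and a 1.0-fold higher number from compound 3 to compound 4 (0.01 log units; within the scatter) and a 1.4-fold higher number from compound 1 to compound 4 (0.15 log units; within the scatter) all lie within the scatter of this assay. The flat picture at this amine nitrogen therefore reaches beyond exchanges of one aryl group for another: cyclohexyl, a non-aromatic ring, cannot be told apart from any of the three aryl groups, so among these four compounds an aromatic ring at this position makes no measurable difference. Nothing given here accounts for this lack of separation.

From the compounds shown here alone, it stays open whether a group of another kind on this nitrogen, such as an amine, a carboxylic acid or a longer chain, would move the number beyond the scatter. All four compounds also keep the same core, so the compounds shown say nothing about changes elsewhere in the structure.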